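The source may report more compounds than this note shows. Statements on the series, on what has been measured and on what is new or still open speak of the compounds shown alone.

Compound 2 `Cc1cc(-c2ccccc2)c(S(C)(=O)=O)cc1C(=O)N=C(N)N` is the stronger of the two compounds measured in a functional assay for inhibition of sodium/hydrogen exchanger (Oryctolagus cuniculus); on this read-out lower numbers stand for stronger inhibition and higher numbers for weaker inhibition; in that assay compound 2 gives 19 nM. Compound 1 `Cc1c(C(=O)N=C(N)N)cc(S(C)(=O)=O)c(C)c1C` gives 55 nM in this assay, a higher and therefore weaker value than that of compound 2. Compound 3 `Cc1cc(Oc2cccc(Cl)c2)c(S(C)(=O)=O)cc1C(=O)N=C(N)N` has not yet been measured. It differs from compound 2 in a single place: 3-chlorophenoxy in place of phenyl on an aromatic carbon. Because compound 2 gives 19 nM, compound 3 is expected to land close by, with the step of a 1.6-fold higher number from compound 2 to compound 3 (0.20 log units; within the scatter) estimated as a modest loss of inhibition, near the edge of the scatter. The estimate for compound 3 is 30 nM, with a range from 8 nM to 120 nM.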

Compound 3, half-maximal inhibitory concentration: 21 nM
Estimate against measurement, compound 3: 1.4-fold (0.15 log units) above; low and high end bracket the measured number.
By their numbers in this assay, from the lowest: compounds 2 and 3 (each within the scatter of the next); then compound 1.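

In this assay, putting 3-chlorophenoxy in place of phenyl on this aromatic carbon, ortho to a methylsulfonyl group, gives a 1.1-fold higher number from compound 2 to compound 3 (0.04 log units; within the scatter) and so leaves the two compounds indistinguishable. This position therefore tolerates a group with more heavy atoms, including an oxygen link and a chlorine, without a measurable loss of inhibition. No measured evidence here explains why the two groups read alike.

As far as these compounds go, it remains open how an unsubstituted phenoxy group would compare, and so whether the chlorine contributes anything. A small amine or a carboxylic acid at this position is also an open question.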